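The compounds below may be only part of what the source reports. "The series", "measured", "known", "first", "only" and "open" are said of these compounds alone.

Compound 1, `CCCOC(=O)Nc1ccc(S(=O)(=O)N2C[C@H](c3ccccc3)NC2=O)cc1CC`: in a functional assay on HCT-116 cells (Homo sapiens) for cytotoxicity, read by MTT assay (a higher number here means a weaker inhibitor, a lower number a stronger inhibitor), compound 1 gives 60 nM.
Compound 2, `Cc1cc(S(=O)(=O)N2C(=O)N[C@@H](c3ccccc3)C2C)ccc1NC(=O)c1ccc([N+](=O)[O-])cc1`: in this assay compound 2 reaches only the limit of the assay, > 10000 nM, and no number.
Compound 3, `CCc1cc(S(=O)(=O)N2C[C@H](c3ccccc3)NC2=O)ccc1NC(=O)NC1CCCCC1`: in this assay compound 3 gives 300 nM.

Among the two numbers shown, compound 3 stands highest; its nearest neighbour is compound 1, and the step of a 5.0-fold higher number from compound 1 to compound 3 (0.70 log units; beyond the scatter) separates them, the only measured step in this set. Among the measured compounds shown here, compound 2 sits at a limit, (the limit of > 10000 nM in this assay, at which 1 of the 3 values shown sits), and contributes no step. Compound 4, `CCOC(=O)Nc1ccc(S(=O)(=O)N2C[C@H](c3ccccc3)NC2=O)cc1CC`, has not yet been measured. The change from compound 3 to compound 4 is ethoxy in place of cyclohexylamino on a carbonyl carbon. This change largely undoes the measured step, since the cyclohexylamino that entered from compound 1 to compound 3 now leaves, and an alkoxy returns, here ethoxy instead of propoxy. Compound 4 is therefore expected to move back toward compound 1, with a step of roughly a 3.8-fold lower number from compound 3 to compound 4 (0.57 log units; beyond the scatter), a lower number in this assay. The estimate for compound 4 is 80 nM, with a likely range from 30 nM to 250 nM.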

Compound 4, half-maximal inhibitory concentration: 70 nM
Compound 4: the middle estimate sits 1.1-fold (0.06 log units) above what was measured; the measured number falls inside the stated range.
By their numbers in this assay, from the lowest: compounds 1 and 4 (each within the scatter of the next); then compound 3. At a limit, above all of these: compound 2.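

In this assay, replacing cyclohexylamino with ethoxy on this carbonyl carbon gives a 4.3-fold lower number from compound 3 to compound 4 (0.63 log units; beyond the scatter), so the difference seen with propoxy also appears with a second alkoxy group. The length of the alkoxy chain makes no discernible difference at this level, with propoxy and ethoxy separated by a 1.2-fold higher number from compound 1 to compound 4 (0.07 log units; within the scatter). Nothing shown here accounts for either step. The compounds leave open whether the lower numbers follow the oxygen or the absence of the cyclohexyl ring, a question that an ethylamino or a cyclohexyloxy group on the same carbonyl carbon would address. They also leave open how far the alkoxy chain can vary, from a methoxy group to a longer chain such as butoxy or hexyloxy.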